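Replacing the ureido tail of compound 2

The source may hold more compounds than are shown below. What is called first, only, known or untested is meant among the compounds shown, and "the series" means these compounds.

Compound 1 `NC/C=C\CN(C[C@H]1Cc2ncccc2CN1)[C@H]1CCCc2cccnc21` gives 11%
Compound 2 `NC(=O)NCCCCN(C[C@H]1Cc2ncccc2CN1)[C@H]1CCCc2cccnc21` gives 1%
Compound 3 `NC(=O)NC/C=C/CN(C[C@H]1Cc2ncccc2CN1)[C@H]1CCCc2cccnc21` gives 1%

All three values come from an ADME assay on microsomes from liver (Rattus norvegicus) for metabolic stability, using NADPH, with a stated time of 10 min (on this read-out higher numbers stand for a more stable compound and lower numbers for a less stable compound), and belong to compounds sharing one core. Compound 2 stands level with compound 3 at the digits shown, with no change at the digits printed from compound 2 to compound 3 (within the scatter) as the step between them. Compound 1 lies within the scatter of both, as a number 10 percentage points lower from compound 1 to compound 2 (within the scatter) and a number 10 percentage points lower from compound 1 to compound 3 (within the scatter) show.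

Compound 4 `c1cnc2c(c1)CN[C@@H](CN(CCCCN(C1COC1)C1COC1)[C@H]1CCCc3cccnc31)C2` has not yet been measured. Its change from compound 2 is a group of 9 heavy atoms (6 carbon, 1 nitrogen, 2 oxygen; 2 four-membered non-aromatic rings with 1 hetero atom each) in place of a group of 4 heavy atoms (1 carbon, 2 nitrogen, 1 oxygen; no ring), on a saturated chain carbon, four bonds along the chain from an amine nitrogen and so the ureido leaves and two four-membered non-aromatic rings enter. These three steps bear on the change. Each exchanges the group at this end of the chain, yet none lies beyond the scatter. None of them brings in such rings, so they guide the expectation only loosely. The expected step is a number 4 percentage points higher from compound 2 to compound 4 (within the scatter) and so none beyond the scatter. The estimate for compound 4 is 5% within an expected range of 1% to 18% on this read-out.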

Compound 4, percent of the compound remaining: 72%
Compound 4: middle estimate off by 67 percentage points, on the low side; the whole stated range lies below it.
By their numbers in this assay, from the lowest: compounds 2, 3 and 1 (each within the scatter of the next); then compound 4.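

For the compounds shown here, with a number 71 percentage points higher from compound 2 to compound 4 (beyond the scatter) in this assay, this position, on a saturated chain carbon, four bonds along the chain from an amine nitrogen, proves able to carry a large change, something the earlier steps, all within the scatter, did not show. The exchange removes the ureido and its hydrogen-bond donors and brings in 2 four-membered non-aromatic rings with 1 hetero atom each, so the step belongs to the whole entering group and not to any one of its features. No measurement offered here accounts for the size of this step.

The compounds shown leave open whether the step depends on the rings themselves or on the amine nitrogen that carries them, a question that a dimethylamino group at this place would address. They also leave open whether the same group would behave alike on the unsaturated chain of compound 3.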